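Replacing a Hydroxy Group on a Hydroxamic Acid Side Chain

The source may report more compounds than this note shows. Statements on the series, on what has been measured and on what is new or still open speak of the compounds shown alone.

Measured compounds in a physicochemical assay for solubility; on this read-out higher numbers stand for higher solubility and lower numbers for lower solubility:
- compound 1 `O=C(N[C@@H](CO)C(=O)NO)c1ccc(C#Cc2ccccc2)cc1`: 28000 nM
- compound 2 `O=C(NC1(C(=O)NO)CCCCC1)c1ccc(C#Cc2ccccc2)cc1`: < 1000 nM
- compound 3 `O=C(NC1(C(=O)NO)CCS(=O)(=O)CC1)c1ccc(C#Cc2ccccc2)cc1`: 2000 nM

All three share the same core, and they differ in the group that carries the hydroxamic acid. Compound 1 gives the higher of the two numbers measured in this assay. The nearest number is that of compound 3, which lies well below compound 1, a gap beyond the usual scatter of repeated measurements. Compound 2 does not give a number at all: its result is a limit of the assay, (the limit of < 1000 nM in this assay, at which 1 of the 3 values shown sits).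

Compound 4 `COCCNC(=O)C[C@H](NC(=O)c1ccc(C#Cc2ccccc2)cc1)C(=O)NO` has not yet been measured. It differs from compound 1 in one place: (2-methoxyethyl)carbamoyl in place of hydroxy on a saturated chain carbon, two bonds along the chain from an amide-type nitrogen and a carbonyl carbon. Going by the values given here, no direct step between two measured compounds matches this change, so the expectation rests on what compound 1 shows and on the size of the change itself, which adds a chain and an amide-type group while removing the hydroxy group.

For compound 4 the solubility is expected to be moderately lower than for compound 1, a step that may stay within the scatter or only slightly beyond it, with a 1.9-fold lower number from compound 1 to compound 4 (0.27 log units; within the scatter). Compound 4 is therefore estimated at 15000 nM, within a range from 4000 nM to 45000 nM.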

Compound 4, solubility: 78000 nM
Beside the measured number, compound 4's estimate is 5.2-fold (0.72 log units) below it; measured number outside the range, above it.
By their numbers in this assay, from the lowest: compound 3; then compound 1; then compound 4. At a limit, below all of these: compound 2.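

Among the compounds shown, this is the first comparison in which only one place changes, so it gives the first direct look at this saturated chain carbon, two bonds along the chain from an amide-type nitrogen and a carbonyl carbon. In this assay, putting (2-methoxyethyl)carbamoyl in place of hydroxy gives a 2.8-fold higher number from compound 1 to compound 4 (0.44 log units; beyond the scatter) and so shows that this position can carry a far larger group, with 7 heavy atoms instead of 1, while the number rises rather than falls. Nothing in the data given accounts for why the number moves this way.

As far as these compounds go, what remains open is which part of the new group goes with the rise: the carbamoyl unit itself or the 2-methoxyethyl chain on its nitrogen. A plain primary carbamoyl, a carboxylic acid or an amine on this same carbon would help to separate these parts, and a longer chain with a second ether oxygen would show whether the number keeps moving in the same direction.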